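The compounds below may be only part of what the source reports. "The series", "measured", "known", "first", "only" and "open" are said of these compounds alone.

Compound 3 `O=C(Nc1cccc(-n2cc(-c3ccncc3)c(-c3ccc(Cl)c(O)c3)n2)c1)Nc1ccc(Cl)c(Cl)c1` gives 14300 nM in a functional assay on CAKI-1 cells (Homo sapiens) for inhibition, read by sulforhodamine B assay, with a stated time of 48 h (a higher number here means a weaker inhibitor of growth, a lower number a stronger inhibitor of growth), the highest of the three numbers. Compound 2 `COc1cc(-c2nn(-c3cccc(NC(=O)Nc4ccc(Cl)c(Cl)c4)c3)cc2-c2ccncc2)ccc1Cl` gives 3700 nM, and the change from compound 2 to compound 3 is a hydroxyl in place of a methoxy: a 3.9-fold higher number from compound 2 to compound 3 (0.59 log units; beyond the scatter). Compound 1 `COc1cc(-c2nn(-c3cccc(NC(=O)Nc4cc(C(F)(F)F)cc(C(F)(F)F)c4)c3)cc2-c2ccncc2)ccc1Cl` gives 3140 nM; compound 1 and compound 2 differ only in the groups at the same end of the molecule that changes here, and their two values lie within the scatter of each other. Compound 4 `O=C(Nc1cccc(-n2cc(-c3ccncc3)c(-c3ccc(Cl)c(O)c3)n2)c1)Nc1ccc(Cl)c(C(F)(F)F)c1` differs from compound 3 by trifluoromethyl in place of chloro on an aromatic carbon. Among the compounds with values here, no measured step touches this position directly; the only guide is the pair of compounds 1 and 2, whose values show no difference beyond the scatter. Compound 4 is therefore expected to stay close to compound 3. The expected step of a 1.0-fold lower number from compound 3 to compound 4 (0.01 log units; within the scatter) lies within the scatter. The estimate for compound 4 is 14000 nM, between 7000 nM and 28000 nM.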

Compound 4, concentration for total growth inhibition: 2630 nM
Compound 4: the middle estimate sits 5.3-fold (0.73 log units) above what was measured, outside the stated range (below it).
By their numbers in this assay, from the lowest: compounds 4, 1 and 2 (each within the scatter of the next); then compound 3.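

In this assay, replacing 3,4-dichlorophenyl with 4-chloro-3-(trifluoromethyl)phenyl gives a 5.4-fold lower number from compound 3 to compound 4 (0.74 log units; beyond the scatter), so a single group at this end of the molecule can move the number beyond the scatter. Compound 1 and compound 2 did not show this, since their values lie within the scatter of each other. No measurement here accounts for the step. The compounds shown leave open whether trifluoromethyl in place of chloro has the same effect with a methoxy in place of the hydroxyl, and how a nitrile or an amine would read at this position.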